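This account rests on a few compounds, and the source may have more. Where it says the series, first, only, none or still open, it means among the compounds named here.

Compound 1 `Fc1ccc(-c2nc3cnc(Nc4ccccn4)cc3[nH]2)cc1C(F)(F)F`: in a physicochemical assay for solubility, using the shake flask method, in simulated intestinal fluid, measured as kinetic solubility, with a stated time of 20 h, at pH 6.5 (on this read-out higher numbers stand for higher solubility and lower numbers for lower solubility), compound 1 reaches >= 50000 nM, which is a limit of the assay and not a number.
Compound 2 `Fc1ccc(-c2nc3cnc(Nc4ccccn4)cc3[nH]2)cc1F`: in this assay compound 2 reaches >= 50000 nM, again a limit rather than a number.

Within the data shown here, compound 2 therefore stands at the limit of >= 50000 nM in this assay, at which 2 of the 2 values shown sit, together with compound 1, and the single measured step that the two limits leave unreadable from compound 1 to compound 2 cannot be read in size or direction. Compound 3 `Fc1ccc(Nc2cc3[nH]c(-c4ccc(F)c(F)c4)nc3cn2)nc1` differs from compound 2 by fluoro in place of hydrogen on an aromatic carbon. Among the measured compounds shown here, the one measured step bears on this change only loosely, and it gives no readable size, so no direction can be taken from it. With both known compounds at the same limit, the step of a number no higher from compound 2 to compound 3 (the limit leaves the size open) is expected to stay within the scatter. Compound 3 is estimated at 50000 nM, between 20000 nM and 100000 nM, most likely reported once more as a limit.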

Compound 3, solubility: >= 50000 nM
Compound 3 ended at the assay's limit; the forecaster's own chance of this, stated with the estimate: 75%; the middle value lies on the limit itself.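

Compound 2 and compound 3 both end at a limit of the assay rather than at a number, so no step between them can be read: the limit of >= 50000 nM in this assay, at which 3 of the 3 values shown sit.

The compounds shown leave open how far the true values lie past that limit, and whether (5-fluoropyridin-2-yl)amino in place of (pyridin-2-yl)amino makes any difference in this assay.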